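A few compounds are considered here, and "the series" means these few. Any claim that something is new, unique, unknown or untested is made for them only; others in the source may bear on it.

In a functional assay on the whole organism (heart) with Rattus norvegicus as the target (a higher number here means that more compound is needed for the effect, a lower number that less compound is needed), compound 1 `CC(=O)/C(=C\c1ccccc1)Oc1ccccc1OCCCN1CCN(C)CC1` gives 2.5 mg/kg and compound 2 `CC(=O)/C(=C\c1ccccc1)Oc1ccccc1OCC(O)CNC(C)(C)C` gives 1.9 mg/kg with a 1.3-fold lower number from compound 1 to compound 2 (0.12 log units; within the scatter) as the step between them. Compound 3 `CC(=O)/C(=C\c1ccccc1)Oc1ccccc1OCCCN1CCCCC1` stands lowest of the three at 0.2 mg/kg in this series, and its distance to each of the other two lies beyond the scatter.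

Compound 4 `CC(=O)/C(=C\c1ccccc1)Oc1ccccc1OCCCN(C)C` has yet to be measured, and its difference from compound 3 reads dimethylamino in place of piperidin-1-yl on a saturated chain carbon, three bonds along the chain from an oxygen on an aromatic ring in full. Dimethylamino thus stands in place of piperidin-1-yl, on the same saturated chain carbon, and no ring remains there.

Going by the values given here, two measured steps bear on this change. The closer one keeps the chain and exchanges only the group at its end, and it shows a 13-fold lower number from compound 1 to compound 3 (1.10 log units; beyond the scatter) as a large move. The other gives a 9.5-fold lower number from compound 2 to compound 3 (0.98 log units; beyond the scatter) and is modest. Both end at piperidin-1-yl, so the group that compound 4 gives up belongs to the lowest number seen so far. Neither step involves dimethylamino, so its size remains uncertain.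

A move toward a higher number is expected, smaller than those two steps, and the estimated step is a 3.5-fold higher number from compound 3 to compound 4 (0.54 log units; beyond the scatter) in this reading. For compound 4 the expected value is 0.7 mg/kg with an estimated range of 0.2 mg/kg to 2.5 mg/kg in this assay when it is measured.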

Compound 4, dose for half-maximal effect: 0.37 mg/kg
Beside the measured number, compound 4's estimate is 1.9-fold (0.28 log units) above it; the measured number falls inside the stated range.
By their numbers in this assay, from the lowest: compounds 3 and 4 (each within the scatter of the next); then compounds 2 and 1 (each within the scatter of the next).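

In this assay, a 1.9-fold higher number from compound 3 to compound 4 (0.27 log units; within the scatter) shows that an end group with no ring, dimethylamino, can take the place of piperidin-1-yl on this saturated chain carbon, three bonds along the chain from an oxygen on an aromatic ring, with a step that stays within the scatter. The low number is therefore not confined to piperidin-1-yl, as dimethylamino also stands clear of 4-methylpiperazin-1-yl, with a 6.8-fold lower number from compound 1 to compound 4 (0.83 log units; beyond the scatter), and of 1-hydroxy-2-((tert-butyl)amino)ethyl, with a 5.1-fold lower number from compound 2 to compound 4 (0.71 log units; beyond the scatter). Compounds 3 and 4 thus form one group and compounds 1 and 2 another, but no measurement at hand explains this separation.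

The compounds shown leave open whether a morpholin-4-yl or diethylamino group on the same chain would fall with compounds 3 and 4 or with compounds 1 and 2. They also leave open how the hydroxyl on the chain and the tert-butylamino group each contribute in compound 2, and whether a shorter ethyl or longer butyl chain would keep the numbers of compounds 3 and 4.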